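The source may hold more compounds than are shown below. What is called first, only, known or untested is meant among the compounds shown, and "the series" means these compounds.

Measured so far:
compound 1 `N#CC1=C(NC(=O)/C=C/c2ccccc2)N(c2ccc(S(N)(=O)=O)cc2)C2=C(C(=O)CCC2)C1c1ccc(Cl)cc1Cl`, > 100 ug/mL
compound 2 `N#CC1=C(NC(=O)c2ccc([N+](=O)[O-])cc2)N(c2ccc(S(N)(=O)=O)cc2)C2=C(C(=O)CCC2)C1c1ccc(Cl)cc1Cl`, 50 ug/mL

Compound 1 gives only a limit in a functional assay on Ehrlich cells (Mus musculus) for cytotoxicity, read by trypan blue exclusion, with a stated time of 2 h (on this read-out lower numbers stand for stronger inhibition and higher numbers for weaker inhibition), namely > 100 ug/mL, and no number. In this assay, among the measured compounds shown here, compound 2 gives 50 ug/mL, the only number. For the measured compounds named here, the step of an at least 2.0-fold lower number from compound 1 to compound 2 (0.30 log units; that floor lies within the scatter) is the sole measured step, and it starts from the limit (the limit of > 100 ug/mL in this assay, at which 1 of the 2 values shown sits), so its true size is unknown; its floor lies within the scatter. Going by the values given here, compound 2 therefore stands as the one compound with a determined value.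

Compound 3 `COc1cc(C(=O)NC2=C(C#N)C(c3ccc(Cl)cc3Cl)C3=C(CCCC3=O)N2c2ccc(S(N)(=O)=O)cc2)cc(OC)c1OC` differs from compound 2 by 3,4,5-trimethoxyphenyl in place of 4-nitrophenyl on a carbonyl carbon. Among the compounds with values here, only the step from compound 1 to compound 2 concerns the same carbonyl carbon, and it tells nothing beyond the scatter. Within the data shown here, no measured step describes exchanging one aromatic ring for another on this carbonyl carbon, so no direction can be taken from the data. The step of a 1.2-fold higher number from compound 2 to compound 3 (0.08 log units; within the scatter) is therefore estimated as none beyond the scatter, with wide uncertainty. Compound 3 is expected to give about 60 ug/mL in this assay, between 20 ug/mL and 150 ug/mL, with a real chance that only a limit is reported.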

Compound 3, half-maximal inhibitory concentration: 60 ug/mL
The estimate for compound 3 equals the measured number at the digits printed; measured number inside the range.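

In this assay, among the compounds shown here, the step of a 1.2-fold higher number from compound 2 to compound 3 (0.08 log units; within the scatter) gives the first exchange on this carbonyl carbon that can be read between two determined values, and it shows no difference beyond the scatter. The exchange is a substantial one in composition: 3,4,5-trimethoxyphenyl, with 12 heavy atoms and no nitrogen, enters where 4-nitrophenyl, with 9 heavy atoms, leaves, and the six-membered aromatic ring of carbon is the feature the two groups share. The step of an at least 1.6-fold lower number from compound 1 to compound 3 (0.22 log units; that floor lies within the scatter) adds little, since it has no known true size and its floor lies within the scatter: the limit of > 100 ug/mL in this assay, at which 1 of the 3 values shown sits.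

For the compounds shown here, the two determined values come from only two aromatic groups, so it stays open whether any group on this carbonyl carbon, such as 4-aminophenyl, 4-carboxyphenyl or a plain butyl chain, would move the number beyond the scatter. As far as these compounds go, how far compound 1, with its 2-phenylethenyl group, truly lies from compound 2 and compound 3 also stays open.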